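Swapping a methoxyphenyl ring for an isopropylphenyl ring

The compounds below may be only part of what the source reports. "The series", "measured", "known", "first", "only" and "open" are said of these compounds alone.

Measured in a physicochemical assay for lipophilicity, read by HPLC, at pH 7.5; on this read-out lower numbers stand for lower lipophilicity and higher numbers for higher lipophilicity:
Compound 1 `CC[C@@H](Nc1c(C#N)c(-c2ccc(-c3cccc(C)c3F)cc2)nc2cnccc12)C(N)=O`: 3
Compound 2 `CC[C@@H](Nc1c(C#N)c(-c2ccc(-c3ccccc3OC)cc2)nc2cnccc12)C(N)=O`: 2.7
Compound 3 `CC[C@@H](Nc1c(C#N)c(-c2ccc(-c3cccc(OC)c3)cc2)nc2cnccc12)C(N)=O`: 2.7

Compound 3 stands level with compound 2, and compound 1 sits within the usual scatter of both. The next compound is compound 4 `CC[C@@H](Nc1c(C#N)c(-c2ccc(-c3ccccc3C(C)C)cc2)nc2cnccc12)C(N)=O`, and the change is 2-isopropylphenyl in place of 3-methoxyphenyl on an aromatic carbon. In words, 2-isopropylphenyl comes in place of 3-methoxyphenyl. For the measured compounds named here, three measured steps concern this same ring: a number 0.30 log units lower from compound 1 to compound 2 (within the scatter), a number 0.30 log units lower from compound 1 to compound 3 (within the scatter) and no change at the digits printed from compound 2 to compound 3 (within the scatter). All are small, and none involves an isopropyl group, so they guide only loosely. Going by the values given here, the entering group holds no oxygen, and compound 1, the only measured compound without a methoxy group, gives 3. An upward move is therefore expected, and the expected step is a number 0.50 log units higher from compound 3 to compound 4 (beyond the scatter). For compound 4 the estimate is 3.2, with an expected range from 2.8 to 3.6.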

Compound 4, distribution coefficient: 3.5
Beside the measured number, compound 4's estimate is 0.30 log units below it, within the range that was stated.
By their numbers in this assay, from the lowest: compounds 2, 3 and 1 (each within the scatter of the next); then compound 4.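

In this assay, for the compounds shown here, isopropyl in place of methoxy gives the first steps on this ring that lie beyond the scatter (a number 0.80 log units higher from compound 2 to compound 4 (beyond the scatter); a number 0.80 log units higher from compound 3 to compound 4 (beyond the scatter)). Compound 1 also carries no methoxy, yet a step beyond the scatter remains (a number 0.50 log units higher from compound 1 to compound 4 (beyond the scatter)), so losing methoxy is not the whole story here. No measurement shown accounts for these steps. Still open, on these data alone, is how a longer chain, an amine or a carboxylic acid on this ring would read in this assay.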